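Chloro for Fluoro on Two Hydrazide Cores

The source may hold more compounds than are shown below. What is called first, only, known or untested is meant among the compounds shown, and "the series" means these compounds.

Measured so far:
Compound 1, `N=C(N)Nc1cccc(C(=O)NNC(=O)NC(CC(=O)O)c2ccc(F)cc2)c1`, in a physicochemical assay for lipophilicity (on this read-out lower numbers stand for lower lipophilicity and higher numbers for higher lipophilicity), gives 0.86.
Compound 2, `N=C(N)Nc1cccc(C(=O)NNC(=O)NC(CC(=O)O)c2ccc(Cl)cc2)c1`, in this assay gives 1.26.
Compound 3, `O=C(O)CC(CC(=O)NNC(=O)CCCCNc1ccccn1)c1ccc(F)cc1`, in this assay gives 2.23.

Compounds 1 and 2 share one core and differ in a single place: chloro in place of fluoro on an aromatic carbon. This change gives a number 0.40 log units higher from compound 1 to compound 2 (beyond the scatter). Compound 3 is built on a different core; the difference between the two cores is not broken down here. Its value in this assay is the highest of the three, and the gaps to compound 2 and compound 1 are both beyond the scatter.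

Compound 4, `O=C(O)CC(CC(=O)NNC(=O)CCCCNc1ccccn1)c1ccc(Cl)cc1`, has not yet been measured in this assay. It differs from compound 3 in a single place: chloro in place of fluoro on an aromatic carbon. Going by the values given here, the place of the change is the same in both pairs, so this is the same change as the one from compound 1 to compound 2, now made on the core of compound 3.

For compound 4 the step expected from compound 3 is a number 0.40 log units higher from compound 3 to compound 4 (beyond the scatter), set beside the earlier one, because the same change gave a number 0.40 log units higher from compound 1 to compound 2 (beyond the scatter). This rests on a single measured pair, so the match may be loose. Compound 4 is therefore estimated at 2.63 in this assay, expected to lie between 2.3 and 2.95.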

Compound 4, partition coefficient: 2.63
The estimate for compound 4 equals the measured number at the digits printed; measured number inside the range.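

In this assay the change from 4-fluorophenyl to 4-chlorophenyl gives a number 0.40 log units higher from compound 3 to compound 4 (beyond the scatter) on the core of compound 3, and this stands level with a number 0.40 log units higher from compound 1 to compound 2 (beyond the scatter) on the core of compound 1. Within these four compounds, then, the step carried over from one core to the other without any visible loss or gain, and on both cores it lies beyond the scatter. The agreement rests on only two pairs and a single read-out, however, so it shows that the change transferred here, not that it would transfer to a further core, and nothing shown explains why the two steps agree.

The compounds shown leave open whether a bromo or a methyl group in the same place on the aromatic ring would also give matching steps on the two cores. They also leave open whether the chloro-for-fluoro step would keep its size on a core that lacks the carboxylic acid, or on one that carries a longer chain than compound 3 does.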